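The source may report more compounds than this note shows. Statements on the series, on what has been measured and on what is new or still open speak of the compounds shown alone.

Measured compounds:
compound 1 `Nc1ccnc2c1nc(-c1ccccc1)n2CCN1CCCCC1` — in an assay on isolated protein for inhibition of high affinity 3',5'-cyclic-AMP phosphodiesterase 7A (Homo sapiens), read by cAMP accumulation, with a stated time of 20 min (a lower number here means a stronger inhibitor, a higher number a weaker inhibitor), compound 1 gives > 200000 nM, a limit of the assay.
compound 2 `CCCCCn1c(-c2ccco2)nc2c(NCCOC)ccnc21` — in this assay compound 2 gives > 200000 nM, again a limit of the assay.
compound 3 `COCCNc1ccnc2c1nc(-c1ccco1)n2C1CCCC1` — in this assay compound 3 gives 119000 nM.

Within the data shown here, compound 3 thus carries the only number among the three; the other two results are limits, (the limit of > 200000 nM in this assay, at which 2 of the 3 values shown sit). Among the measured compounds shown here, the one measured step, an at least 1.6-fold lower number from compound 2 to compound 3 (0.22 log units; that floor lies within the scatter), runs from a limit to a number and its floor lies within the scatter, so it says nothing firm about the size of any change.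

Compound 4 `COCCCNc1ccnc2c1nc(-c1ccco1)n2C1CCCC1` differs from compound 3 by methoxymethyl in place of methoxy on a saturated chain carbon, two bonds along the chain from a nitrogen on an aromatic ring. For the measured compounds named here, no measured step touches this chain; the single step in the set concerns the group on the aromatic nitrogen. Nothing shown therefore supports a change beyond the scatter in this assay in either direction. For compound 4 the expected value in this assay is 120000 nM, with a range of 50000 nM to 300000 nM. The step expected from compound 3 to compound 4 is a 1.0-fold higher number from compound 3 to compound 4 (0.00 log units; within the scatter), that is, no step beyond the scatter. With the limit of > 200000 nM in this assay, at which 2 of the 3 values shown sit, in view, an outcome for compound 4 reported only as a limit remains possible.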

Compound 4, half-maximal inhibitory concentration: 90500 nM
The estimate for compound 4 lay 1.3-fold (0.12 log units) above the measured number; the measured number falls inside the stated range.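

Going from (2-methoxyethyl)amino to (3-methoxypropyl)amino gives a 1.3-fold lower number from compound 3 to compound 4 (0.12 log units; within the scatter) in this assay and shows that this position accepts methoxymethyl in place of methoxy with no step beyond the scatter. Among these compounds, this is the first step that joins two numbers and can therefore be read for size; it also bears on the chain, whereas the only earlier step concerned the group on the aromatic nitrogen and started from a limit. Among the compounds shown here, compound 3 and compound 4 both give numbers, while the remaining results are limits, so the flat step describes only this narrow pair and not the series as a whole: the limit of > 200000 nM in this assay, at which 2 of the 4 values shown sit.

On these data alone, whether an amine or a carboxylic acid in place of methoxy, or a chain longer than 3-methoxypropyl, would move the number beyond the scatter in this assay remains open. Also open, as far as these compounds go, is whether the chain behaves the same way when the cyclopentyl on the aromatic nitrogen is replaced, for example by a cyclohexyl or a benzyl group.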